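Swapping a Halogen for Methyl on the Terminal Ring

This account rests on a few compounds, and the source may have more. Where it says the series, first, only, none or still open, it means among the compounds named here.

Among the compounds with values here, compound 2 `Oc1ccccc1/C=N/c1nnc(SCc2nnc(-c3ccc(Cl)cc3)o2)s1` is one of two compounds so far measured in a functional assay on A549 cells (Homo sapiens) for inhibition, read by CCK-8 assay; a higher number here means a weaker inhibitor, a lower number a stronger inhibitor. In that assay compound 2 gives 30100 nM, the higher of the two numbers in hand. Its only companion, compound 1 `Oc1ccccc1/C=N/c1nnc(SCc2nnc(-c3ccc(F)cc3)o2)s1`, carries fluoro where compound 2 carries chloro, and in this assay compound 1 gives 20100 nM. The step between the two, a 1.5-fold higher number from compound 1 to compound 2 (0.18 log units; within the scatter), shows that putting chloro in place of fluoro on that aromatic carbon left the read-out within the usual scatter of repeats.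

Compound 3 `Cc1ccc(-c2nnc(CSc3nnc(/N=C/c4ccccc4O)s3)o2)cc1` has not yet been measured. It differs from compound 2 by methyl in place of chloro on an aromatic carbon. Within the data shown here, the one measured step that bears on this change is a 1.5-fold higher number from compound 1 to compound 2 (0.18 log units; within the scatter): a single small group exchanged at the same place, with no movement beyond the scatter. Among the measured compounds shown here, no measured step speaks to methyl itself. On that basis the expected change in this assay is none beyond the scatter, that is a 1.1-fold lower number from compound 2 to compound 3 (0.03 log units; within the scatter). Compound 3 is therefore estimated at 28000 nM, with a likely range from 12000 nM to 65000 nM.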

Compound 3, half-maximal inhibitory concentration: 22000 nM
For compound 3 the middle estimate is 1.3-fold (0.10 log units) above the measured one; the measured number falls inside the stated range.
By their numbers in this assay, from the lowest: compounds 1, 3 and 2 (each within the scatter of the next).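

Within the data shown here, compound 3 is the first to put something other than a halogen on this aromatic carbon, and in this assay the exchange gives a 1.4-fold lower number from compound 2 to compound 3 (0.14 log units; within the scatter) and a 1.1-fold higher number from compound 1 to compound 3 (0.04 log units; within the scatter). Methyl, a carbon group, therefore cannot be told apart from chloro or from fluoro at this position, so compounds 1, 2 and 3 cannot be ranked, and a halogen is not needed here for the number to stay within the scatter of the others. Nothing measured alongside these numbers offers an explanation for this result.

The compounds shown leave open whether any group on this carbon, such as an amine, a carboxylic acid or a longer chain, would move the number beyond the scatter, or whether this position simply makes little difference to the read-out. Also open, on these data alone, is what the bare ring would give with only hydrogen on this carbon, since a comparison with that compound would show whether fluoro, chloro and methyl each differ from having no group there at all.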